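The compounds below may be only part of what the source reports. "The series", "measured", "known", "first", "only" and "open" are said of these compounds alone.

In a functional assay on Hep 3B2 cells (Homo sapiens) for inhibition, read by MTT assay, with a stated time of 72 h (a lower number here means a stronger inhibitor, a higher number a weaker inhibitor), compound 1 (`Nc1nc2cc(-c3nn(CCCCCCCCCC(=O)NO)c4ncnc(N)c34)ccc2o1`) gives 28800 nM, and compound 2 (`Nc1ncnc2c1c(-c1cnc3[nH]ccc3c1)nn2CCCCCCCCCC(=O)NO`) gives 17200 nM. Within the data shown here, these are the only two numbers available. The step between them is a 1.7-fold lower number from compound 1 to compound 2 (0.22 log units; within the scatter), so the two compounds stand level and compound 1 cannot be separated from compound 2.

Compound 3 (`Nc1nc2cc(-c3nn(CCCCCCCCC(=O)NO)c4ncnc(N)c34)ccc2o1`) keeps the core of compound 1 and differs only at the end of the chain: hydroxycarbamoyl in place of (hydroxycarbamoyl)methyl on a saturated chain carbon, eight bonds along the chain from an aromatic nitrogen. Hydroxycarbamoyl stands in place of (hydroxycarbamoyl)methyl on a saturated chain carbon, eight bonds along the chain from an aromatic nitrogen.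

Among the measured compounds shown here, the one measured step changes the group on an aromatic carbon and leaves the chain as it is, so it bears on this change only indirectly. For the measured compounds named here, no measured pair differs in the chain, and the data therefore fix no direction. A change beyond the scatter is not expected, and the range is kept wide. The expected step is a 1.2-fold lower number from compound 1 to compound 3 (0.08 log units; within the scatter), which would stay within the scatter. For compound 3 the estimated value is 24000 nM, with an expected range from 8000 nM to 60000 nM.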

Compound 3, half-maximal inhibitory concentration: 8890 nM
Beside the measured number, compound 3's estimate is 2.7-fold (0.43 log units) above it; the measured number falls inside the stated range.
By their numbers in this assay, from the lowest: compounds 3, 2 and 1 (each within the scatter of the next, the first and the last beyond it).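

Among these compounds, the end of the chain is the first place in this set where a single change moves the number in this assay beyond the scatter: with hydroxycarbamoyl in place of (hydroxycarbamoyl)methyl on a saturated chain carbon, eight bonds along the chain from an aromatic nitrogen, the result is a 3.2-fold lower number from compound 1 to compound 3 (0.51 log units; beyond the scatter). The earlier change, on an aromatic carbon, gave a 1.7-fold lower number from compound 1 to compound 2 (0.22 log units; within the scatter), which stayed within the scatter, so the chain now counts as a position where the number in this assay can respond, though the step is modest and rests on a single pair. Nothing measured here accounts for the size or the direction of this step.

A single pair cannot show whether a still shorter chain would carry the number lower, or whether the response to chain length follows any trend at all. As far as these compounds go, it also remains open whether the same shortening would act alike on the core of compound 2, and how a carboxylic acid at the end of the chain, in place of hydroxycarbamoyl, would stand in this assay.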